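A Ring Swap and the Expected Cell Toxicity

The source may report more compounds than this note shows. Statements on the series, on what has been measured and on what is new or still open speak of the compounds shown alone.

Compound 1 (`COc1nc(-c2ccccc2F)ccc1[C@@H](c1ccccc1)[C@@](O)(CCN(C)C)c1cccc2ccccc12`) and compound 2 (`COc1nc(-c2ccncc2)ccc1[C@@H](c1ccccc1)[C@@](O)(CCN(C)C)c1cccc2ccccc12`) share one core and differ in a single ring. In a toxicity assay on HeLa cells (Homo sapiens) for cytotoxicity (on this read-out lower numbers stand for higher toxicity in this test and higher numbers for lower toxicity in this test), compound 1 has no reported result ("nd" (no result reported)). In this assay, within the data shown here, compound 2 gives a value (9.6 ug/mL), the only number available, so it cannot yet be ranked as high or low against any other compound. A single value offers a starting point, not a trend.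

In compound 3 (`COc1nc(-c2ccc(Cl)c(F)c2)ccc1[C@@H](c1ccccc1)[C@@](O)(CCN(C)C)c1cccc2ccccc12`), 4-chloro-3-fluorophenyl stands in place of pyridin-4-yl on an aromatic carbon (4-chloro-3-fluorophenyl in place of pyridin-4-yl on an aromatic carbon). Among the measured compounds shown here, no measured pair shows what such a swap does in this test, and compound 1 offers no number for comparison. The data therefore set no direction for the change. The expected step is small (a 1.1-fold lower number from compound 2 to compound 3 (0.05 log units; within the scatter)) and no larger than the usual scatter of repeated measurements. For compound 3 the estimated value is (8.5 ug/mL), with an expected range running from (3.5 ug/mL) to (22 ug/mL). That wide range reflects how little the available data can say.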

Compound 3, half-maximal cytotoxic concentration: > 64 ug/mL
Compound 3 ended at the assay's limit (the forecaster's own chance of this, stated with the estimate: 15%); middle value at least 7.5-fold (0.87 log units) from the limit.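

In this assay the change from pyridin-4-yl to 4-chloro-3-fluorophenyl gives an at least 6.6-fold higher number from compound 2 to compound 3 (0.82 log units; beyond the scatter) and so lies beyond the usual scatter, which means lower toxicity in this test for the new ring. Compound 3 gives > 64 ug/mL here, which is a limit of the assay and not a number. This first readable step shows that the group on this aromatic carbon, next to the ring nitrogen, can matter for the read-out, although the step marks only the smallest change consistent with the data and its full size stays unknown: the limit of > 64 ug/mL in this assay, at which 1 of the 3 values shown sits.

The compounds shown leave open which part of the swap counts, since the ring nitrogen leaves while a chlorine and a fluorine enter in the same step. They also leave open how this position would respond to a plain phenyl ring with neither halogen, or to a ring carrying an amine or a carboxylic acid, and whether any such group would keep the read-out as high as it stands for the 4-chloro-3-fluorophenyl ring.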